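The compounds below may be only part of what the source reports. "The series", "measured", "known", "first", "only" and "open" are said of these compounds alone.

Among the measured compounds shown here, compound 1 `COC(=O)C(C)n1nc2c(n1)C(=O)C(C)=C(C)C2=O` is one of two compounds measured in a functional assay on HeLa cells (Homo sapiens) for inhibition, read by colorimetric assay, with a stated time of 72 h; a lower number here means that less compound is needed, a higher number that more compound is needed for the effect. In this assay compound 1 gives 0.9 ug/mL, which is the higher of the two numbers, while compound 2 `COC(=O)Cn1nc2c(n1)C(=O)C(C)=CC2=O` gives 0.5 ug/mL; the two values lie within the scatter of each other, so no order between them can be claimed. Compound 3 `CC1=C(C)C(=O)c2nn(C)nc2C1=O` has not yet been measured. It differs from compound 1 in one place: methyl in place of 1-(methoxycarbonyl)ethyl on an aromatic nitrogen. For the measured compounds named here, no step between measured compounds shows what this change does, and the two measured values give no direction to follow. The loss of the 1-(methoxycarbonyl)ethyl group is expected to cost a little, so the step from compound 1 to compound 3 is estimated as a modest rise, a 2.0-fold higher number from compound 1 to compound 3 (0.30 log units; within the scatter), not far beyond the scatter. Compound 3 is therefore expected to give about 1.8 ug/mL in this assay, with a plausible range from 0.5 ug/mL to 6 ug/mL.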

Compound 3, concentration for half-maximal effect: 0.5 ug/mL
Compound 3: the middle estimate sits 3.6-fold (0.56 log units) above what was measured, within the range that was stated.
By their numbers in this assay, from the lowest: compounds 2, 3 and 1 (each within the scatter of the next).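

In this assay, among the compounds shown here, putting methyl in place of 1-(methoxycarbonyl)ethyl on the aromatic nitrogen gives a 1.8-fold lower number from compound 1 to compound 3 (0.26 log units; within the scatter), and this is the first direct reading of a change at this position. The core of compound 1 was kept, so the step isolates this one group. A single methyl thus serves as well as the larger group here: removing most of the side chain, including its carbonyl and both oxygen atoms, produces no difference that can be told from the scatter.

On these data alone, it remains open whether an amine, a carboxylic acid or a longer carbon chain on this nitrogen would move the number beyond the scatter. Why the two groups read alike also stays open, as nothing measured here gives a reason for this result.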